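Shortening the basic chain of compound 2

The source may report more compounds than this note shows. Statements on the series, on what has been measured and on what is new or still open speak of the compounds shown alone.

Two measured compounds share one core. Compound 1 `C=CCOc1ccc2c(NCCCN(C)C)ccnc2c1` carries a three-carbon chain ending in a dimethylamino group, and in a functional assay on RKO cells (Homo sapiens) for cytotoxicity, read by MTT assay, with a stated time of 48 h (on this read-out lower numbers stand for stronger inhibition and higher numbers for weaker inhibition), compound 1 gives 3560 nM. Compound 2 `CCOc1ccc2c(NCCCN(C)C)ccnc2c1` differs from it only in the group on the ring oxygen, and in this assay compound 2 gives 5240 nM. Going by the values given here, the single measured step, a 1.5-fold higher number from compound 1 to compound 2 (0.17 log units; within the scatter), is too small to separate the two, so compound 2 holds the higher of the two numbers without being the weaker compound in any firm sense.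

Compound 3 `CCOc1ccc2c(NCCN(C)C)ccnc2c1` is the next candidate. Its change from compound 2 is dimethylamino in place of (dimethylamino)methyl on a saturated chain carbon, two bonds along the chain from a nitrogen on an aromatic ring. Among the compounds with values here, no measured step touches this chain: the one known step concerns the group on the oxygen and lies within the scatter, so it gives no guide to what trimming the chain does. The expectation for compound 3 therefore rests on compound 2 alone, and the step of a 1.0-fold lower number from compound 2 to compound 3 (0.00 log units; within the scatter) is expected to be small, with a wide range to reflect the missing precedent. Compound 3 is estimated at 5200 nM, between 1800 nM and 15000 nM.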

Compound 3, half-maximal inhibitory concentration in the RKO assay: 3650 nM
Compound 3: the middle estimate sits 1.4-fold (0.15 log units) above what was measured; low and high end bracket the measured number.
By their numbers in the RKO assay, from the lowest: compounds 1, 3 and 2 (each within the scatter of the next).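

In the RKO assay, shortening the chain from 3-(dimethylamino)propyl to 2-(dimethylamino)ethyl gives a 1.4-fold lower number from compound 2 to compound 3 (0.16 log units; within the scatter), so this position on the chain now has a measured step of its own, and like the change on the ring oxygen, this step does not separate the two compounds. In a physicochemical assay for solubility (on this read-out higher numbers stand for higher solubility and lower numbers for lower solubility), compound 2 gives > 10000 ug/mL, which is a limit of the assay and not a number. In the physicochemical assay compound 3 gives > 10000 ug/mL, also a limit, so the step between the two cannot be read: the limit of > 10000 ug/mL in the physicochemical assay, at which 2 of the 2 values shown sit.

The compounds shown leave open whether a longer chain, such as 4-(dimethylamino)butyl, or another amine at the chain end, such as diethylamino or morpholine, would move the number in the RKO assay beyond the usual scatter. They also leave open whether a chain ending in a carboxylic acid instead of an amine would keep any activity in the RKO assay, since both chain lengths shown here end in the same dimethylamino group.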